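From Amino to Carbamoyl: What to Expect for Compound 3

A few compounds are considered here, and "the series" means these few. Any claim that something is new, unique, unknown or untested is made for them only; others in the source may bear on it.

Of the compounds shown here, two that share one core have been tested in an assay on isolated protein (strain Sprague-Dawley) for inhibition of Amine oxidase [flavin-containing] B (Rattus norvegicus), read by spectrophotometry, with a stated time of 5 min; a higher number here means a weaker inhibitor, a lower number a stronger inhibitor. Compound 1 `CCCOc1cc(=O)oc2cc(OCc3cccc(F)c3)ccc12` gives 407 nM in this assay. Compound 2 `Nc1cc(=O)oc2cc(OCc3cccc(Cl)c3)ccc12` gives 47.9 nM in this assay, the lower of the two numbers, so compound 2 is the stronger inhibitor of the pair, and the gap to compound 1 lies beyond the usual scatter of repeated measurements. Compound 3 `NC(=O)c1cc(=O)oc2cc(OCc3cccc(Cl)c3)ccc12` has not yet been measured. It differs from compound 2 in one place: carbamoyl in place of amino on an aromatic carbon. Within the data shown here, no measured pair shows what this particular exchange does to the result, so the expectation has to rest on compound 2 alone. A modest weakening is expected, with a step of a 3.1-fold higher number from compound 2 to compound 3 (0.50 log units; beyond the scatter) that may or may not clear the scatter. Compound 3 is therefore expected to give 150 nM in this assay, within a range from 30 nM to 800 nM.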

Compound 3, half-maximal inhibitory concentration: 234 nM
Estimate against measurement, compound 3: 1.6-fold (0.19 log units) below; low and high end bracket the measured number.
By their numbers in this assay, from the lowest: compound 2; then compounds 3 and 1 (each within the scatter of the next).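

In this assay the exchange of amino for carbamoyl on this aromatic carbon, opposite the ring oxygen, gives a 4.9-fold higher number from compound 2 to compound 3 (0.69 log units; beyond the scatter) and so counts as a modest weakening beyond the scatter. This position therefore responds to the group it carries, even though both groups have the same counts of hydrogen-bond donors and acceptors and no net charge, and the inhibitor is weakened rather than lost, with compound 3 at 234 nM in this assay. No measurement at hand gives a reason for this step.

Only these two groups have been compared at this position, so one step cannot show a trend. From the compounds shown here alone, it remains open how a carboxylic acid, a methyl ester or a dimethylamino group on the same carbon would compare.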